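The compounds below may be only part of what the source reports. "The series", "measured", "known", "first", "only" and "open" are said of these compounds alone.

Measured in an ADME assay on HEK293 cells (Homo sapiens) for cytotoxicity, read by CCK-8 assay, with a stated time of 48 h; on this read-out lower numbers stand for stronger inhibition and higher numbers for weaker inhibition:
- Compound 1 `COc1ccc(/C=C\c2cc(OC)c(OC)c(OC)c2)cc1OCc1ccc(CN[C@H](C(=O)O)[C@H](C)O)cc1`: > 50000 nM, a limit and not a number
- Compound 2 `COc1ccc(/C=C\c2cc(OC)c(OC)c(OC)c2)cc1OCc1ccc(CNCCN(C)C)cc1`: 39000 nM

Among the measured compounds shown here, compound 2, at 39000 nM, holds the only exact number so far. Compound 3 `COc1ccc(/C=C\c2cc(OC)c(OC)c(OC)c2)cc1OCc1ccc(CNCCNC(C)=O)cc1` carries acetamido in place of dimethylamino on a saturated chain carbon, two bonds along the chain from an amine nitrogen. For the measured compounds named here, the one measured step, an at least 1.2-fold lower number from compound 1 to compound 2 (0.10 log units; that floor lies within the scatter), changed the whole group on that amine nitrogen, so it is only a loose guide. On that basis, no step beyond the scatter is expected in this assay. The expected change is a 1.2-fold higher number from compound 2 to compound 3 (0.06 log units; within the scatter). For compound 3 the estimate is 45000 nM, with an expected range of 22000 nM to 90000 nM.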

Compound 3, half-maximal inhibitory concentration: > 50000 nM
Compound 3: a limit, no number; the forecaster's own chance of this, stated with the estimate: 45%; middle value at least 1.1-fold (0.04 log units) away from the limit.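

Acetamido in place of dimethylamino on this saturated chain carbon gives an at least 1.2-fold higher number from compound 2 to compound 3 (0.10 log units; that floor lies within the scatter) and so does not bring the reading down. Compound 3 stands at > 50000 nM and that is a limit, not a number, so the true size of this change stays hidden, and the step between the two limits cannot be read. Only compound 2 has an exact number, and the others stop at one shared ceiling: the limit of > 50000 nM in this assay, at which 2 of the 3 values shown sit.

From the compounds shown here alone, whether a primary amine or a longer chain at this place would give an exact number remains open.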